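Triazole-bearing lactone series: antiproliferative notes, compound 2 to compound 4

A few compounds are considered here, and "the series" means these few. Any claim that something is new, unique, unknown or untested is made for them only; others in the source may bear on it.

Measured so far:
compound 1, `O=C1O/C(=C\Cn2cc(-c3cc(F)cc(F)c3)nn2)C(OCc2ccccc2)=C1OCc1ccccc1`: > 100000 nM
compound 2, `O=C1O[C@H]([C@@H](O)Cn2cc(CCO)nn2)C(OCc2ccccc2)=C1OCc1ccccc1`: 72700 nM
compound 3, `O=C1O/C(=C\Cn2cc(-c3cc(C(F)(F)F)cc(C(F)(F)F)c3)nn2)C(OCc2ccccc2)=C1OCc1ccccc1`: > 100000 nM

In a functional assay on HCT-116 cells (Homo sapiens) for antiproliferative activity, read by MTT assay, with a stated time of 72 h (a lower number here means a stronger inhibitor, a higher number a weaker inhibitor), compound 1 returns only a limit, > 100000 nM, not a number. Compound 3 likewise returns only a limit, > 100000 nM. Going by the values given here, compound 2 is the single compound with a numerical result in this assay, 72700 nM, and it therefore stands as the sole reference point; no step between measured compounds can be written, since two of the three results sit at the limit of > 100000 nM in this assay, at which 2 of the 3 values shown sit.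

Compound 4, `CCCCCCCCCCc1cn(C[C@H](O)[C@H]2OC(=O)C(OCc3ccccc3)=C2OCc2ccccc2)nn1`, differs from compound 2 as follows: octyl in place of hydroxy on a saturated chain carbon, two bonds along the chain from an aromatic carbon. Nothing measured here tells how a change of this kind moves the read-out, so the expectation rests on compound 2 alone. A modest gain in this assay is expected. The expected step in this assay is a 3.6-fold lower number from compound 2 to compound 4 (0.56 log units; beyond the scatter). Compound 4 is estimated at 20000 nM, with a plausible range from 5000 nM to 80000 nM.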

Compound 4, half-maximal inhibitory concentration: 28800 nM
The estimate for compound 4 lay 1.4-fold (0.16 log units) below the measured number, within the range that was stated.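

In this assay, this position now has its first readable step: octyl in place of hydroxy on a saturated chain carbon, two bonds along the chain from an aromatic carbon, gives a 2.5-fold lower number from compound 2 to compound 4 (0.40 log units; beyond the scatter). The same difference reads as 2-hydroxyethyl to decyl, so at this position the terminal hydroxy can be lost and the chain lengthened with a modest gain in this one pair. Steps to the other compounds cannot be read, because they give no number: the limit of > 100000 nM in this assay, at which 2 of the 4 values shown sit.

The change removes the hydroxy and lengthens the chain in one move, and the two contributions cannot be separated from this pair. A hexyl chain, a dodecyl chain or a terminal amine at this position would show whether the trend continues and which part of the change carries it.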